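Bromo-to-chloro exchange on the nitrophenyl arm of compound 3

The compounds below may be only part of what the source reports. "The series", "measured", "known", "first", "only" and "open" are said of these compounds alone.

Three measured compounds of this series, compound 1 `COc1cc(OC)c(/C=C(/SCc2ccc(Cl)cc2)C(=O)c2ccc(Br)cc2)c(OC)c1`, compound 2 `O=C(O)c1ccc(C(=O)/C(=C\c2ccc(Cl)c([N+](=O)[O-])c2)SCc2ccc(Cl)cc2)cc1` and compound 3 `O=C(O)c1ccc(C(=O)/C(=C\c2ccc(Br)c([N+](=O)[O-])c2)SCc2ccc(Br)cc2)cc1`, sit at one level. In a functional assay on DU-145 cells (Homo sapiens) for inhibition, read by trypan blue exclusion, with a stated time of 96 h (on this read-out lower numbers stand for stronger inhibition of growth and higher numbers for weaker inhibition of growth), compound 1 gives 1000 nM, compound 2 gives 1000 nM, and compound 3 gives 1000 nM; these values lie within the scatter of one another, so no order among the three is read from them. Compound 4 `O=C(O)c1ccc(C(=O)/C(=C\c2ccc(Cl)c([N+](=O)[O-])c2)SCc2ccc(Br)cc2)cc1` is the next member, not yet tested in this assay. Its difference from compound 3 is chloro in place of bromo on an aromatic carbon. Compound 2 already carries chloro at that place and is level with compound 3, so the step from compound 3 to compound 4 is expected to stay within the scatter, no change at the digits printed from compound 3 to compound 4 (within the scatter). Compound 4 is accordingly estimated at 1000 nM, with a range from 500 nM to 2000 nM.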

Compound 4, concentration for 50% growth inhibition: 500 nM
Compound 4: middle estimate off by 2.0-fold (0.30 log units), on the high side; the range from low to high includes it.
By their numbers in this assay, from the lowest: compounds 4, 1, 2 and 3 (each within the scatter of the next).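

In this assay, exchanging 4-bromo-3-nitrophenyl for 4-chloro-3-nitrophenyl gives a 2.0-fold lower number from compound 3 to compound 4 (0.30 log units; within the scatter), and bromo in place of chloro on the other halogen-bearing aromatic ring gives a 2.0-fold lower number from compound 2 to compound 4 (0.30 log units; within the scatter). Among the compounds shown here, these are the only single-place steps, and each halogen exchange, taken alone, stays within the scatter. The data offer no explanation for either step.

As far as these compounds go, whether an amine or a methoxy group, on the aromatic carbon ortho to the nitro group, would also stay within the scatter remains open. So does the outcome of replacing the carboxylic acid with an amide.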